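Working notes: from selenium-linked aryl to hydroxybutynyl

This account rests on a few compounds, and the source may have more. Where it says the series, first, only, none or still open, it means among the compounds named here.

Measured in a functional assay on Jurkat cells (Homo sapiens) for cytotoxicity, read by MTT assay, with a stated time of 24 h; on this read-out lower numbers stand for an effect already at smaller amounts and higher numbers for an effect only at larger amounts of compound:
- compound 1 `CCOC(=O)c1cc([Se]c2ccc(F)cc2)c2cc(OC)ccc2n1`: 134000 nM
- compound 2 `CCOC(=O)c1cc(C#Cc2ccc(N)cc2)c2cc(OC)ccc2n1`: 61000 nM
- compound 3 `CCOC(=O)c1cc([Se]c2ccccc2)c2cc(OC)ccc2n1`: 102000 nM

Compound 3, at 102000 nM, stands second highest of the three numbers and lies within the scatter of both compound 1 and compound 2. The next structure is compound 4 `CCOC(=O)c1cc(C#CCCO)c2cc(OC)ccc2n1`. The change is a group of 5 heavy atoms (4 carbon, 1 oxygen; no ring) in place of a group of 7 heavy atoms (6 carbon, 1 selenium; one six-membered aromatic ring of carbon only), on an aromatic carbon. The group that enters is 4-hydroxybut-1-yn-1-yl, and it sits on the aromatic carbon opposite the ring nitrogen.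

Within the data shown here, only one measured step bears on this series so far: a 1.3-fold lower number from compound 1 to compound 3 (0.12 log units; within the scatter). That step exchanges fluoro for hydrogen on the ring that leaves here, so it shows no more than a flat response to that small exchange. Among the measured compounds shown here, no measured step tests the replacement itself. For the measured compounds named here, compound 2 is the only measured compound with a triple bond outside aromatic rings, and at 61000 nM it gives the closest available reference. All three numbers lie close together, which gives no ground for expecting a large move. The expected change is small, estimated as a 1.3-fold lower number from compound 3 to compound 4 (0.11 log units; within the scatter). For compound 4 the estimated value in this assay is 80000 nM, with an expected range of 35000 nM to 180000 nM.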

Compound 4, half-maximal effective concentration: 123000 nM
The estimate for compound 4 lay 1.5-fold (0.19 log units) below the measured number; low and high end bracket the measured number.
By their numbers in this assay, from the lowest: compounds 2, 3, 4 and 1 (each within the scatter of the next, the first and the last beyond it).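

In this assay, the aromatic carbon opposite the ring nitrogen accepts 4-hydroxybut-1-yn-1-yl in place of the selenium-linked aryl group with only a 1.2-fold higher number from compound 3 to compound 4 (0.08 log units; within the scatter) and, for the fluorinated aryl group, a 1.1-fold lower number from compound 1 to compound 4 (0.04 log units; within the scatter) as the result. Neither the selenium nor the aromatic ring of the leaving group is therefore needed to keep the number within the scatter, a point that the fluoro-for-hydrogen step between the two selenium compounds could not address. Among the triple-bonded compounds, 2-hydroxyethyl in place of 4-aminophenyl gives a 2.0-fold higher number from compound 2 to compound 4 (0.30 log units; within the scatter) and so also produces no step beyond the scatter, while the measurements offer no explanation for this flat response.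

The compounds shown leave open whether any group at this position can move the number beyond the scatter, for example an amine or a carboxylic acid in place of the hydroxyl at the end of the 4-hydroxybut-1-yn-1-yl chain, or a longer chain carrying the same hydroxyl. Also open, as far as these compounds go, is whether a carboxylic acid in place of the ethoxycarbonyl group would change the response to these exchanges.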